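This account rests on a few compounds, and the source may have more. Where it says the series, first, only, none or still open, it means among the compounds named here.

Going by the values given here, compound 1 (`CC(=O)N1N=C(c2ccccc2)CC1c1cccc(Cl)c1Cl`) gives 31600 nM in a functional assay on PC-3 cells (Homo sapiens) for cytotoxicity, read by sulforhodamine B assay, with a stated time of 48 h (on this read-out higher numbers stand for weaker inhibition and lower numbers for stronger inhibition), and stands highest of the two numbers so far. Compound 2 (`COc1ccc(C2CC(c3ccco3)=NN2C(C)=O)cc1`) gives 15500 nM as the lower number, a gap beyond the usual scatter. Compound 3 (`CC(=O)N1N=C(c2ccco2)CC1c1cccc(Cl)c1Cl`) is the core of compound 1 with furan-2-yl in place of phenyl on a carbon with a double bond to nitrogen. Among the compounds with values here, no measured step covers this change. Compound 2 also carries furan-2-yl and gives 15500 nM but differs elsewhere, so only a small shift to lower numbers is expected in this assay and it may stay within the scatter. The expected size is estimated as a 1.4-fold lower number from compound 1 to compound 3 (0.16 log units; within the scatter) for this change. For compound 3 the estimated value is 22000 nM with 9000 nM to 50000 nM as the expected range.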

Compound 3, half-maximal inhibitory concentration: 61200 nM
Compound 3: the middle estimate sits 2.8-fold (0.44 log units) below what was measured, and the stated range ends below it.
By their numbers in this assay, from the lowest: compound 2; then compounds 1 and 3 (each within the scatter of the next).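

Furan-2-yl in place of phenyl on a carbon with a double bond to nitrogen gives a 1.9-fold higher number from compound 1 to compound 3 (0.29 log units; within the scatter) in this assay, so on the core of compound 1 the two rings cannot be told apart at this position. This step gives no support for reading the number of compound 2 as an effect of furan-2-yl. Nothing at hand bears on why the two rings read alike.

On these data alone, it remains open whether a ring carrying an amine or a carboxylic acid at this position would move the number beyond the scatter, and whether the change reads alike on the core of compound 2.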